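Dropping the methyl from the shared core: what to expect

This account rests on a few compounds, and the source may have more. Where it says the series, first, only, none or still open, it means among the compounds named here.

Measured so far:
- compound 1 `Cn1ccc2c(Oc3ccc(NC(=O)c4cn(-c5ccc(Cl)cc5)c5ccccc5c4=O)cc3F)ccnc21`: 2120 nM
- compound 2 `Cn1ccc2c(Oc3ccc(NC(=O)c4cn(-c5ccc(Br)cc5F)c5ccccc5c4=O)cc3F)ccnc21`: 420 nM
- compound 3 `Cn1ccc2c(Oc3ccc(NC(=O)c4cn(-c5ccc(F)c(Cl)c5)c5ccccc5c4=O)cc3F)ccnc21`: "not determined" (no result reported)

In a functional assay on MCF7 cells (Homo sapiens) for inhibition, read by MTT assay, with a stated time of 72 h (on this read-out higher numbers stand for weaker inhibition and lower numbers for stronger inhibition), compound 2 gives the lowest number of the two compounds with values; the nearest is compound 1, and the step of a 5.0-fold lower number from compound 1 to compound 2 (0.70 log units; beyond the scatter) lies beyond the scatter. Compound 4 `O=C(Nc1ccc(Oc2ccnc3[nH]ccc23)c(F)c1)c1cn(-c2ccc(Br)cc2F)c2ccccc2c1=O` differs from compound 2 in one place: hydrogen in place of methyl on an aromatic nitrogen. Among the compounds with values here, no measured step touches this position, so the only step known, a 5.0-fold lower number from compound 1 to compound 2 (0.70 log units; beyond the scatter), concerns another part of the molecule and gives no guidance here. With nothing to lean on, compound 4 is expected to land near compound 2, a step of a 1.2-fold lower number from compound 2 to compound 4 (0.08 log units; within the scatter) in this assay, in either direction within the scatter. The estimate for compound 4 is 350 nM, with a range from 100 nM to 1300 nM.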

Compound 4, half-maximal inhibitory concentration: 1390 nM
Compound 4: middle estimate off by 4.0-fold (0.60 log units), on the low side; measured number above the stated range.
By their numbers in this assay, from the lowest: compound 2; then compounds 4 and 1 (each within the scatter of the next).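

Within the data shown here, replacing the methyl on the aromatic nitrogen with hydrogen in this assay gives a 3.3-fold higher number from compound 2 to compound 4 (0.52 log units; beyond the scatter), so this position, untouched by the earlier steps, does respond to change. Of the two groups shown here, methyl gives the stronger inhibition. No measurement at hand explains this difference. Going by these compounds, whether a group larger than methyl, such as ethyl or a longer chain, would strengthen or weaken inhibition at this nitrogen remains open. So does whether the same step would appear with the 4-chlorophenyl group of compound 1 in place of the 4-bromo-2-fluorophenyl group.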